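The compounds below may be only part of what the source reports. "The series", "measured", "known", "first", "only" and "open" are said of these compounds alone.

Series values in an ADME assay on Jurkat cells (Homo sapiens) for cytotoxicity, read by trypan blue exclusion, with a stated time of 24 h; on this read-out lower numbers stand for stronger inhibition and higher numbers for weaker inhibition:

- compound 1 `N#C[Se]c1ccc(N)cc1`: 43800 nM
- compound 2 `N#C[Se]Cc1ccccc1[N+](=O)[O-]`: 12900 nM
- compound 3 `N#C[Se]Cc1ccc(Br)cc1`: 12700 nM

Compound 3 gives the lowest of the three numbers at 12700 nM, but compound 2 at 12900 nM lies within the scatter of it, so the two cannot be ordered. Compound 1 at 43800 nM stands higher than compound 3, and that gap lies beyond the scatter.

The next compound is compound 4 `Cc1ccc(C[Se]C#N)cc1`, not yet measured. Its difference from compound 3 is methyl in place of bromo on an aromatic carbon, para to a group of 4 heavy atoms.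

Within the data shown here, no measured pair differs in one place only, so the data hold no direct measure of this change. Among the measured compounds shown here, the only guide is indirect: compound 2 at 12900 nM and compound 3 at 12700 nM differ in more than one place, yet their values fall within the scatter. In this assay no step beyond the scatter is therefore expected, and the estimated change is small: a 1.2-fold higher number from compound 3 to compound 4 (0.07 log units; within the scatter). For compound 4 the expected half-maximal inhibitory concentration is 15000 nM, with an estimated range of 8000 nM to 27000 nM.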

Compound 4, half-maximal inhibitory concentration: 14400 nM
Beside the measured number, compound 4's estimate is 1.0-fold (0.02 log units) above it; low and high end bracket the measured number.
By their numbers in this assay, from the lowest: compounds 3, 2 and 4 (each within the scatter of the next); then compound 1.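

The pair gives the series its first direct reading of a single change: in this assay, methyl in place of bromo on an aromatic carbon, para to a group of 4 heavy atoms, gives a 1.1-fold higher number from compound 3 to compound 4 (0.05 log units; within the scatter). At this position, bromo and methyl cannot be told apart on this read-out, so the bromine is not required for the number seen with compound 3, and a carbon substituent of the same heavy-atom count serves equally. Nothing available accounts for this match, and it stands as an observation only.

With one pair at this position, the reading covers only these two single-atom groups, and a carboxylic acid, a methoxy group or a longer chain on the same aromatic carbon could still give a step beyond the scatter. Compound 1 differs from compound 3 in more than one place, so its higher number cannot be assigned to one group, and an amine at this position on the core of compound 3 would separate those places.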